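Working notes: compound 2 to compound 4, ester for amide

The compounds below may be only part of what the source reports. "The series", "measured", "known", "first", "only" and "open" are said of these compounds alone.

compound 1 `CCOC(=O)Nc1sc(-c2ccc(Cl)cc2)c(-c2ccc(Cl)cc2)c1C(=O)NC1CC1` — 39800 nM in a functional assay on A549 cells (Homo sapiens) for inhibition, read by sulforhodamine B assay, with a stated time of 72 h; a lower number here means a stronger inhibitor, a higher number a weaker inhibitor
compound 2 `CCCCNC(=O)c1c(N)sc(-c2ccc(Cl)cc2)c1-c1ccc(Cl)cc1` — 8170 nM in this assay
compound 3 `CC(=O)Nc1sc(-c2ccc(Cl)cc2)c(-c2ccc(Cl)cc2)c1C(=O)N1CCCCC1` — 6010 nM in this assay

Compound 2 stands second highest of the three numbers. Compound 3 sits within the scatter of it; compound 1 gives a clearly higher number, beyond the scatter. Compound 4 `COC(=O)c1c(N)sc(-c2ccc(Cl)cc2)c1-c1ccc(Cl)cc1` has not yet been measured. It differs from compound 2 in one place: methoxy in place of butylamino on a carbonyl carbon. Among the measured compounds shown here, no pair of measured compounds isolates this change, since compounds 1 and 3 also differ from compound 2 at the amino group, so no measured step guides the expectation. A modest rise in the number is expected, with an estimated step of a 1.8-fold higher number from compound 2 to compound 4 (0.26 log units; within the scatter), roughly at the edge of the scatter. Compound 4 is estimated at 15000 nM, in a range from 4000 nM to 60000 nM.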

Compound 4, half-maximal inhibitory concentration: 5040 nM
For compound 4 the middle estimate is 3.0-fold (0.47 log units) above the measured one; the measured number falls inside the stated range.
By their numbers in this assay, from the lowest: compounds 4, 3 and 2 (each within the scatter of the next); then compound 1.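

In this assay, methoxy in place of butylamino on a carbonyl carbon gives a 1.6-fold lower number from compound 2 to compound 4 (0.21 log units; within the scatter) and so leaves the number in the same range. At this position, the butylamino group, with its chain and its hydrogen-bond donor, is not needed to hold that range, which compound 1 and compound 3 could not show, as both also differ from compound 2 at the amino group. Nothing available accounts for this result.

Open, from the compounds shown here alone, is whether a carboxylic acid or a primary amide on this carbonyl carbon stays in the same range. Also open, going by these compounds, is whether a longer chain on the ester oxygen does.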